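This account rests on a few compounds, and the source may have more. Where it says the series, first, only, none or still open, it means among the compounds named here.

Measured so far in an ADME assay on Vero cells (Chlorocebus sabaeus) for cytotoxicity, read by crystal violet staining; a lower number here means that less compound is tolerated, a higher number that more compound is tolerated:
compound 1, `FC(F)(F)c1cccc(/N=N/N2CCCC2)c1`: > 100000 nM
compound 2, `c1ccc(/N=N/N2CCN(c3ccccc3)CC2)cc1`: >= 100000 nM

Both entries are limits of this assay rather than numbers. For compound 1 the value > 100000 nM is a limit (the limit of > 100000 nM in this assay, at which 1 of the 2 values shown sits). For compound 2 the value >= 100000 nM is likewise a limit (the limit of >= 100000 nM in this assay, at which 1 of the 2 values shown sits). Among the compounds with values here, compound 2 therefore stands at the upper edge of what this assay reports, and the one further value shown sits at the same kind of edge, so no step within or beyond the scatter can be read between the two measured compounds.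

Compound 3, `CCOC(=O)N1CCN(/N=N/c2ccccc2)CC1`, is the next compound of the series and is yet to be measured. It differs from compound 2 by ethoxycarbonyl in place of phenyl on an amine nitrogen in a ring. The core is kept; only the group on the ring nitrogen is exchanged. Within the data shown here, no measured step is available to set the size of this change. The step of a number no higher from compound 2 to compound 3 (the limit leaves the size open) is expected to be none beyond the scatter. Compound 3 is expected to give 100000 nM, within the range 30000 nM to 300000 nM, and most probably again only as a limit of this assay.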

Compound 3, half-maximal cytotoxic concentration: 90000 nM
Compound 3: the middle estimate sits 1.1-fold (0.05 log units) above what was measured, within the range that was stated.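

In this assay compound 3 gives 90000 nM as a measured number, which shows that a reading inside the reported range is possible in this series with the core kept and only the group on the ring nitrogen exchanged. Within the data shown here, the exchange removes the six-membered aromatic ring from this position and brings in 2 hydrogen-bond acceptors, and the data give an at least 1.1-fold lower number from compound 2 to compound 3 (0.04 log units; that floor lies within the scatter) as the only reading of this change, so no effect of ethoxycarbonyl in place of phenyl can be claimed from this pair. As far as these compounds go, the true size of the step stays open because compound 2 gives no number in this assay, only a limit: the limit of >= 100000 nM in this assay, at which 1 of the 3 values shown sits.

The compounds shown leave open how the read-out responds on this ring nitrogen to a group such as a carboxylic acid, a primary amine on a short chain or a longer alkyl ester in place of the ethyl of ethoxycarbonyl. They also leave open whether a chloro or methoxy group on the phenyl kept in the core of compound 3 would move the number beyond the scatter.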